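The source may report more compounds than this note shows. Statements on the series, on what has been measured and on what is new or still open speak of the compounds shown alone.

Measured compounds in this assay:
- compound 1 `CCN1C(=O)/C(=C/c2cc(Cc3ccccc3Cl)ccc2O)SC1=S`: 46000 nM
- compound 3 `CCOC(=O)C1=C(Nc2ccc([N+](=O)[O-])cc2)S/C(=C\c2ccc(N(C)C)cc2)C1=O`: 141000 nM
- compound 2 `O=C1NC(=S)S/C1=C\c1ccc(Cl)cc1`: a limit of the assay, > 200000 nM

In an assay for inhibition of LL-diaminopimelate aminotransferase, chloroplastic (Arabidopsis thaliana) (a higher number here means a weaker inhibitor, a lower number a stronger inhibitor), compound 1 holds the lowest of the two numbers; the nearest number, that of compound 3, is higher by a margin beyond the scatter. The result for compound 2 is a limit, not a number. Compound 4 `CCN1C(=O)/C(=C/c2ccccc2O)SC1=S` has not been measured. It differs from compound 1 by hydrogen in place of 2-chlorobenzyl on an aromatic carbon: the 2-chlorobenzyl leaves and hydrogen enters. Among the compounds with values here, no measured step of this kind exists. The step from compound 1 to compound 4 is expected to go toward a higher number, well beyond the scatter, as a 4.3-fold higher number from compound 1 to compound 4 (0.64 log units; beyond the scatter) states. Compound 4 is therefore estimated at 200000 nM, with a range from 60000 nM to 600000 nM. An outcome at the limit of > 200000 nM in this assay, at which 1 of the 3 values shown sits, is a real possibility.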

Compound 4, half-maximal inhibitory concentration: > 200000 nM
Compound 4: a limit, no number (the forecaster's own chance of this, stated with the estimate: 50%); the middle value sits exactly at the limit.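

In this assay, within the data shown here, hydrogen in place of 2-chlorobenzyl on the aromatic carbon para to a hydroxy group gives an at least 4.3-fold higher number from compound 1 to compound 4 (0.63 log units; beyond the scatter), the first one-place step. Within this pair, the measurable inhibition of compound 1 therefore depends on the 2-chlorobenzyl. Compound 4 is a limit of the assay, so the step has only a lower bound: the limit of > 200000 nM in this assay, at which 2 of the 4 values shown sit.

From the compounds shown here alone, it remains open whether the benzyl or its chlorine accounts for the difference, and whether a plain benzyl, a methyl or an amine at this carbon would retain any inhibition. Among these compounds, no step here addresses replacing the hydroxy group.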